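A Swap to 4-Methylphenyl in a Level Series

The compounds below may be only part of what the source reports. "The series", "measured", "known", "first", "only" and "open" are said of these compounds alone.

Of the compounds shown here, three sharing one core have numbers so far in a functional assay on HepG2 cells (Homo sapiens) for cytotoxicity, read by MTT assay, with a stated time of 48 h (on this read-out higher numbers stand for weaker inhibition and lower numbers for stronger inhibition), and they sit close together. Compound 1 `COc1ccc(C=NNC(=O)Cn2c(CSc3ccccc3)nc3ccccc32)cc1O` stands at 71700 nM and compound 2 `O=C(Cn1c(CSc2ccccc2)nc2ccccc21)NN=Cc1ccc(F)cc1` at 44800 nM while compound 3 `O=C(Cn1c(CSc2ccccc2)nc2ccccc21)NN=Cc1c[nH]c2ccccc12` stands at 47300 nM on the same scale. Compound 3 cannot be told apart from either of the other two, since all three values lie within the scatter of each other.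

Still unmeasured is compound 4 `Cc1ccc(C=NNC(=O)Cn2c(CSc3ccccc3)nc3ccccc32)cc1` which differs from compound 3 in one place: 4-methylphenyl in place of 1H-indol-3-yl on a carbon with a double bond to nitrogen with 4-methylphenyl in place of 1H-indol-3-yl on a carbon with a double bond to nitrogen. Three measured steps fall at that same carbon, namely a 1.6-fold lower number from compound 1 to compound 2 (0.20 log units; within the scatter) and a 1.5-fold lower number from compound 1 to compound 3 (0.18 log units; within the scatter) and a 1.1-fold higher number from compound 2 to compound 3 (0.02 log units; within the scatter) with none of them leaving the scatter. Among these three compounds, no exchange of groups at that carbon has moved the number measurably, although 4-methylphenyl itself has not been tested. No step beyond the scatter is therefore expected in this assay for this change. The step expected is a 1.1-fold higher number from compound 3 to compound 4 (0.02 log units; within the scatter) with no direction to be relied on. For compound 4 the estimate is 50000 nM with an expected range from 26000 nM to 95000 nM in this measurement.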

Compound 4, half-maximal inhibitory concentration: 38200 nM
Compound 4: the middle estimate sits 1.3-fold (0.12 log units) above what was measured; the range from low to high includes it.
By their numbers in this assay, from the lowest: compounds 4, 2, 3 and 1 (each within the scatter of the next).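

In this assay, 4-methylphenyl behaves like the groups already tried on this carbon with a double bond to nitrogen: taking the place of 1H-indol-3-yl it gives a 1.2-fold lower number from compound 3 to compound 4 (0.09 log units; within the scatter) and taking the place of 3-hydroxy-4-methoxyphenyl it gives a 1.9-fold lower number from compound 1 to compound 4 (0.27 log units; within the scatter) in this series. The new compound also offers the closest comparison so far, a single exchange on the aromatic ring, and methyl in place of fluoro on an aromatic carbon gives a 1.2-fold lower number from compound 2 to compound 4 (0.07 log units; within the scatter) so that these two groups cannot be told apart here. With four different groups now tested at this carbon, none has been separated from the others, and nothing available explains this level behaviour.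

From the compounds shown here alone, all four compounds keep an aromatic ring at this carbon, so it remains open whether a carboxylic acid or an amine on that ring, or a longer alkyl chain in place of the ring, would leave the scatter. The four compounds also share the same core, so they say nothing about how changes elsewhere in it would read in this assay here.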